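The source may report more compounds than this note shows. Statements on the series, on what has been measured and on what is new or still open speak of the compounds shown alone.

Measured compounds:
Compound 1, `CC[C@H](C)[C@H](NC(=O)CN(c1nc(Cl)nc2[nH]cnc12)C1CC1)C(=O)OCc1ccccc1`: 36.3%
Compound 2, `O=C(O)C[C@H](NC(=O)CN(c1nc(Cl)nc2[nH]cnc12)C1CC1)C(=O)O`: 25.1%

Both numbers come from a functional assay on the whole organism (Tail, strain ICR) with Mus musculus as the target, in the tail flick test, with a stated time of 90 min, at a dose of 25 umol/kg by the oral route; a higher number here means a stronger effect of the compound at the dose given, a lower number a weaker effect. Compound 2 stands lowest of the two; its nearest neighbour is compound 1, whose value lies higher by a gap beyond the usual scatter. Going by the values given here, no step between measured compounds that differ in one place is at hand, so the two values show only that compound 1 sits above compound 2, and nothing about what any single change of a group does in this assay.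

Compound 3, `NC(=O)C[C@H](NC(=O)CN(c1nc(Cl)nc2[nH]cnc12)C1CC1)C(=O)O`, remains to be measured in this assay. It differs from compound 2 as follows: amino in place of hydroxy on a carbonyl carbon. Among the compounds with values here, nothing among the measured compounds tells how amino in place of hydroxy on a carbonyl carbon shifts the read-out, and the change is limited to that one group. Compound 3 is therefore expected to land close to compound 2, with the step of a number 2.9 percentage points higher from compound 2 to compound 3 (within the scatter) expected to lie within the scatter rather than beyond it. Within the data shown here, for compound 3 the estimate is 28%, with a range from 12% to 45% that is wide because no measured step guides it.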

Compound 3, a percentage reported as activity, at one dose (the size of the read-out at that dose, not a potency): 20.1%
For compound 3 the middle estimate is 7.9 percentage points above the measured one; measured number inside the range.
By their numbers in this assay, from the lowest: compounds 3 and 2 (each within the scatter of the next); then compound 1.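

Going by these compounds alone, the step gives the first reading of a single change: in this assay, amino in place of hydroxy on a carbonyl carbon, which turns carboxy into carbamoyl and carboxymethyl into carbamoylmethyl, gives a number 5 percentage points lower from compound 2 to compound 3 (within the scatter). At this place, then, exchanging one heavy atom while the count of hydrogen-bond donors and acceptors stays the same leaves the oral read-out at this dose and time indistinguishable from that of the parent acid. The two compounds can be treated as equal here, with no order between them. Nothing measured here gives a reason for this outcome.

What the compounds shown leave open is whether methoxy or dimethylamino on the same carbonyl carbon would move the number beyond the scatter, and whether the same amino for hydroxy exchange would do so on the carboxy group that compound 3 retains. Within the data shown here, compound 1 differs from the other two in more than one place, so no step to it can be read, and no group can be credited with its value.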